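Bromo to Fluoro: Expecting the Read-out for Compound 4

The source may hold more compounds than are shown below. What is called first, only, known or untested is meant among the compounds shown, and "the series" means these compounds.

Compound 1, `COc1cc(OC)c(C(=O)/C=C/c2ccc(Br)cc2)c(OC)c1`: 9500 nM
Compound 2, `COc1cccc(/C=C/C(=O)c2c(O)cc(OC)cc2OC)c1`: 10300 nM
Compound 3, `COc1cc(O)c(C(=O)/C=C/c2ccccc2SC)c(OC)c1`: 15900 nM

Of the compounds shown here, three have been measured in a functional assay on MCF7 cells (Homo sapiens) for cytotoxicity, with a stated time of 48 h; on this read-out higher numbers stand for weaker inhibition and lower numbers for stronger inhibition. Compound 1 gives the lowest of the three numbers, yet its gaps to compound 2 and to compound 3 both lie within the usual scatter, so no ranking can be drawn among them. Compound 4, `COc1cc(OC)c(C(=O)/C=C/c2ccc(F)cc2)c(OC)c1`, is not yet measured. Set against compound 1 it shows (fluoro in place of bromo on an aromatic carbon). For the measured compounds named here, no measured pair differs in one place, so there is no step on hand to show how this change moves the read-out. In this assay compound 4 is therefore expected to stay close to compound 1, with a 1.5-fold higher number from compound 1 to compound 4 (0.17 log units; within the scatter) expected to remain within the scatter, leaning slightly toward a higher number. Compound 4 is estimated at 14000 nM, in a range from 6000 nM to 40000 nM.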

Compound 4, half-maximal inhibitory concentration: 7700 nM
The estimate for compound 4 lay 1.8-fold (0.26 log units) above the measured number, within the range that was stated.
By their numbers in this assay, from the lowest: compounds 4, 1, 2 and 3 (each within the scatter of the next, the first and the last beyond it).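

For the compounds shown here, this is the first comparison in which only one place changes: fluoro in place of bromo on an aromatic carbon gives a 1.2-fold lower number from compound 1 to compound 4 (0.09 log units; within the scatter) in this assay and so leaves the read-out unresolved. At this position, para to a large group, the two halogens cannot be told apart on the core of compound 1. Nothing on hand offers a reason for this closeness.

Still open, from the compounds shown here alone, is whether a group of another kind at this position, such as an amine or a carboxylic acid, would shift the number beyond the scatter.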